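Piperidine analogue of the pyrazole amide series: expected stability

The compounds below may be only part of what the source reports. "The series", "measured", "known", "first", "only" and "open" are said of these compounds alone.

Compound 1 `Cc1noc(C)c1-c1cc(C(=O)N[C@@H](CCN2CCCCC2)CC(=O)NC2CCC2)nn1C1CCCC1` gives "nd" (no result reported) in an ADME assay on microsomes from liver (Rattus norvegicus, strain Sprague-Dawley) for metabolic stability, read by LC-MS, using NADPH, with a stated time of 30 min, tested at 1 uM (a higher number here means that more of the compound is left, a lower number that less of the compound is left), and compound 2 `O=C(C[C@H](CCNC(=O)C1COC1)NC(=O)c1cc(-c2ccccc2C(F)(F)F)n(C2CCCC2)n1)NC1CCC1` likewise gives "nd" (no result reported) in this assay, so neither gives a reference point. Compound 3 `CC(C)CN(C)CC[C@@H](CC(=O)NC1CCC1)NC(=O)c1cc(-c2ccccc2C(F)(F)F)n(C2CCCC2)n1`, which already carries the 2-(trifluoromethyl)phenyl group, gives 63.6% in this assay. Compound 4 `O=C(C[C@H](CCN1CCCCC1)NC(=O)c1cc(-c2ccccc2C(F)(F)F)n(C2CCCC2)n1)NC1CCC1` arises from compound 1 by the change 2-(trifluoromethyl)phenyl in place of 3,5-dimethyl-1,2-oxazol-4-yl on an aromatic carbon and shares the aryl group of compound 3 and the side chain of compound 1. For the measured compounds named here, with no measured step across this change, the size and direction of the step from compound 1 to compound 4 in this assay cannot be read from the data. Compound 4 is expected to give about 58% in this assay, estimated in the range from 30% to 85%, resting on the value of compound 3 63.6%.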

Compound 4, percent of the compound remaining: 74.6%
Beside the measured number, compound 4's estimate is 16.6 percentage points below it; the measured number falls inside the stated range.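

In this assay, piperidin-1-yl in place of isobutyl(methyl)amino on a saturated chain carbon gives a number 11 percentage points higher from compound 3 to compound 4 (beyond the scatter), so with 2-(trifluoromethyl)phenyl held fixed, this side-chain position moves the read-out. The steps from compound 1 and from compound 2 to compound 4 cannot be read, leaving the effect of the aryl exchange unknown. No available measurement accounts for the step.

Open, as far as these compounds go, is whether the piperidin-1-yl step holds with 3,5-dimethyl-1,2-oxazol-4-yl on the shared core. Also open, from the compounds shown here alone, is how a morpholine or pyrrolidine at this chain end would read in this assay.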